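Bromo to trifluoromethyl on two benzyl-piperidine naphthamides

A few compounds are considered here, and "the series" means these few. Any claim that something is new, unique, unknown or untested is made for them only; others in the source may bear on it.

Measured compounds:
compound 1, `O=C(NC1CCN(Cc2ccc(Br)cc2)CC1)c1cccc2ccccc12`: 44 nM
compound 2, `O=C(NC1CCN(Cc2ccc(C(F)(F)F)cc2)CC1)c1cccc2ccccc12`: 96 nM
compound 3, `O=C(NC1CCN(Cc2cccc(Br)c2)CC1)c1ccc2ccccc2c1`: 36 nM

Of the compounds shown here, three have been measured in an assay on isolated protein for displacement of a labelled ligand from D(4) dopamine receptor (Homo sapiens) (a lower number here means a stronger inhibitor, a higher number a weaker inhibitor), and a fourth, compound 4 with the structure `O=C(NC1CCN(Cc2cccc(C(F)(F)F)c2)CC1)c1ccc2ccccc2c1`, has not. Compound 1 has the structure `O=C(NC1CCN(Cc2ccc(Br)cc2)CC1)c1cccc2ccccc12` and compound 2 the structure `O=C(NC1CCN(Cc2ccc(C(F)(F)F)cc2)CC1)c1cccc2ccccc12`; compound 2 differs from compound 1 by trifluoromethyl in place of bromo on an aromatic carbon, a change that gave a 2.2-fold higher number from compound 1 to compound 2 (0.34 log units; beyond the scatter). Compound 3 has the structure `O=C(NC1CCN(Cc2cccc(Br)c2)CC1)c1ccc2ccccc2c1`; compound 1 and compound 3 are built from the same atoms joined differently, and the difference between the two cores is not broken down here. In this assay compound 3 gives 36 nM, which stands within the scatter of compound 1 and beyond it only against compound 2.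

Compound 4 differs from compound 3 by trifluoromethyl in place of bromo on an aromatic carbon. It is the same kind of change as that from compound 1 to compound 2, but the place is not the same word for word: in the earlier pair the group sits para to a large group, here it sits meta to a large group. Going by the values given here, the only guide to the size of the step is the earlier pair, which gave a 2.2-fold higher number from compound 1 to compound 2 (0.34 log units; beyond the scatter). On that basis the step from compound 3 to compound 4 in this assay is expected to be a 2.2-fold higher number from compound 3 to compound 4 (0.35 log units; beyond the scatter), a modest weakening of the same order. Compound 4 is therefore estimated at 80 nM, with the range 35 nM to 180 nM allowing for the change of place and the usual scatter.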

Compound 4, inhibition constant: 103 nM
For compound 4 the middle estimate is 1.3-fold (0.11 log units) below the measured one; low and high end bracket the measured number.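

In this assay, trifluoromethyl in place of bromo on the aromatic carbon again gave a weaker binder, with a 2.9-fold higher number from compound 3 to compound 4 (0.46 log units; beyond the scatter). Set beside the earlier pair, the change carried over from one core to the other in direction and, as far as two steps can tell, in size: the same change on two cores in this assay, a 2.2-fold higher number (0.34 log units; beyond the scatter) from compound 1 to compound 2 and a 2.9-fold higher number (0.46 log units; beyond the scatter) from compound 3 to compound 4, 1.3-fold (0.12 log units) apart, within the scatter of two such steps

Going by these compounds alone, this does not show that the step is independent of the core or of where the group sits, for it rests on only two pairs in a single assay, and those pairs differ in both the core and the place of the group, so the data cannot separate these two influences.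

The compounds shown leave open how other groups on the same aromatic carbon, such as chloro, methoxy or a nitrile, would compare with bromo and trifluoromethyl on either core. They also leave open whether the step would hold if the single carbon linking the aromatic ring to the ring nitrogen gave way to a longer chain, or if each core carried the group at the place it occupies on the other.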